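The source may report more compounds than this note shows. Statements on the series, on what has been measured and on what is new or still open speak of the compounds shown alone.

Measured compounds:
compound 1, `C=C(Br)C(=O)Nc1cccc(-c2cn3nc(Cc4ccccc4)sc3n2)c1`: 3000 nM
compound 2, `C=C(Br)C(=O)Nc1cccc(-c2cn3nc(-c4ccc(OCC)cc4)sc3n2)c1`: 790 nM

Going by the values given here, in a functional assay on L1210 cells (Mus musculus) for inhibition, read by cell counting, with a stated time of 2 days (on this read-out higher numbers stand for weaker inhibition and lower numbers for stronger inhibition), compound 2 gives the lower of the two numbers, and its only neighbour is compound 1, separated by the step of a 3.8-fold lower number from compound 1 to compound 2 (0.58 log units; beyond the scatter). Compound 3, `C=C(Br)C(=O)Nc1cccc(-c2cn3nc(-c4cccc(OC)c4)sc3n2)c1`, differs from compound 2 in one place: 3-methoxyphenyl in place of 4-ethoxyphenyl on an aromatic carbon. Among the compounds with values here, the single measured step, a 3.8-fold lower number from compound 1 to compound 2 (0.58 log units; beyond the scatter), bears on this change only loosely, since there benzyl was exchanged for an aromatic ring on the same carbon, whereas here one aromatic ring carrying an alkoxy group is exchanged for another. Within the data shown here, no measured pair shows what moving or shortening the alkoxy group does. Compound 3 is therefore expected to stay near compound 2, with a step of a 1.3-fold higher number from compound 2 to compound 3 (0.10 log units; within the scatter) in this assay, which may well lie within the scatter. Compound 3 is estimated at 1000 nM, within 400 nM to 2500 nM.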

Compound 3, half-maximal inhibitory concentration: 580 nM
Beside the measured number, compound 3's estimate is 1.7-fold (0.24 log units) above it; the range from low to high includes it.
By their numbers in this assay, from the lowest: compounds 3 and 2 (each within the scatter of the next); then compound 1.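

In this assay, replacing 4-ethoxyphenyl with 3-methoxyphenyl on the carbon next to the ring nitrogen and the ring sulfur gives a 1.4-fold lower number from compound 2 to compound 3 (0.13 log units; within the scatter) and so leaves the number within the scatter, even though the alkoxy group changes in both place and length. Against the benzyl group of compound 1, the same 3-methoxyphenyl group gives a 5.2-fold lower number from compound 1 to compound 3 (0.71 log units; beyond the scatter) and so lies beyond the scatter, as the 4-ethoxyphenyl group of compound 2 also does. Nothing available explains these numbers.

The compounds shown leave open what each alkoxy change does alone, which 4-methoxyphenyl or 3-ethoxyphenyl would separate. They also leave open whether the alkoxy group matters at all, which plain phenyl or a phenyl ring bearing an amine would test.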